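A few compounds are considered here, and "the series" means these few. Any claim that something is new, unique, unknown or untested is made for them only; others in the source may bear on it.

In an ADME assay on BJ cells (Homo sapiens) for cytotoxicity, read by luminescence, with a stated time of 72 h (on this read-out higher numbers stand for an effect only at larger amounts of compound and lower numbers for an effect already at smaller amounts), compound 1 `CCOC(=O)c1c(-c2cccc(-c3ccccc3)c2)[nH]c2cc(OC)c(OC)cc2c1=O` gives > 21500 nM as a limit of the assay and not a number. Compound 2 `COc1cc2[nH]c(-c3cccc(Oc4ccccc4)c3)c(C(=O)NCCN3CCCC3)c(=O)c2cc1F` gives > 21500 nM as a limit too. Compound 2 thus stands at the limit of > 21500 nM in this assay, at which 2 of the 2 values shown sit, in the data so far. Compound 3 `COCCOC(=O)c1c(-c2cccc(Oc3ccccc3)c2)[nH]c2cc(OC)c(F)cc2c1=O` differs from compound 2 on a carbonyl carbon by 2-methoxyethoxy in place of (2-(pyrrolidin-1-yl)ethyl)amino on a carbonyl carbon in a single change. Within the data shown here, no measured step bears on this change, so a shift no larger than the scatter is expected in this assay with no direction favoured, the estimated step that the limit leaves unreadable from compound 2 to compound 3 being small. For compound 3 the expected value is 25000 nM within an estimated range of 10000 nM to 45000 nM and may well be a limit again.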

Compound 3, half-maximal effective concentration: > 21500 nM
Compound 3 was reported as a limit; the forecaster's own chance of this, stated with the estimate: 75%; the middle value is on the limit's open side.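

Among these compounds, compound 2 and compound 3 each give a limit and not a number, and no step between them can be read. In this assay the compounds shown leave open where any of them truly lies and whether 2-methoxyethoxy in place of (2-(pyrrolidin-1-yl)ethyl)amino changes the read-out at all.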